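Amide-to-urea switch on the shared core

The source may hold more compounds than are shown below. What is called first, only, known or untested is meant among the compounds shown, and "the series" means these compounds.

Of the compounds shown here, two on the shared core have been measured in an assay for binding affinity to 5-hydroxytryptamine receptor 1F (Homo sapiens), read by radioligand binding; a higher number here means a weaker inhibitor, a lower number a stronger inhibitor. Compound 1 `CN1CCC(c2c[nH]c3cnc(NC(=O)c4ccc(F)cc4)cc23)CC1` gives 13 nM in this assay. Compound 2 `CN1CCC(c2c[nH]c3ccc(NC(=O)c4ccc(C#N)cc4)nc23)CC1` gives 7.2 nM in this assay, the lower of the two numbers; the gap between compound 2 and compound 1 is within the scatter, so the two are not separated by these measurements.

Compound 3 `CN1CCC(c2c[nH]c3ccc(NC(=O)Nc4ccc(F)cc4)nc23)CC1` is not yet measured. Relative to compound 2 the change is (4-fluorophenyl)amino in place of 4-cyanophenyl on a carbonyl carbon. For the measured compounds named here, no measured pair in this set carries that change, so its size is not known from data here. Both measured compounds stay within the scatter of each other despite different groups on the carbonyl carbon, which gives no ground to expect a large move in either direction. Compound 3 is expected to give 15 nM in this assay, within 4 nM to 60 nM. The expected step of a 2.1-fold higher number from compound 2 to compound 3 (0.32 log units; beyond the scatter) is at most a small weakening, likely within the scatter.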

Compound 3, inhibition constant: 11 nM
The estimate for compound 3 lay 1.4-fold (0.13 log units) above the measured number; low and high end bracket the measured number.
By their numbers in this assay, from the lowest: compounds 2, 3 and 1 (each within the scatter of the next).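

In this assay, the exchange of 4-cyanophenyl for (4-fluorophenyl)amino on a carbonyl carbon, which turns the amide into a urea, gives a 1.5-fold higher number from compound 2 to compound 3 (0.18 log units; within the scatter). For the compounds shown here, this is the first comparison that differs in one place, since the two earlier compounds differ in more than one, and it shows that this position accepts the amide-to-urea switch with the two compounds left unseparated by the measurements, even though the entering group brings a nitrogen and a fluorine and the leaving group takes its nitrile with it. The data offer no measured basis for explaining why the step is this small.

The exchange alters the linking atom and the ring substituent together, so the contribution of each remains unresolved; a urea keeping the nitrile on the phenyl ring, or an amide carrying 4-fluorophenyl on this same core, would separate them. From the compounds shown here alone, it also remains open whether the result holds beyond aryl groups, for example with a piperidine, a morpholine or a plain alkyl chain on the carbonyl carbon.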